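Trifluoromethyl for fluoro on an aryl piperazine succinimide

The source may report more compounds than this note shows. Statements on the series, on what has been measured and on what is new or still open speak of the compounds shown alone.

Compound 1 `CC(C(=O)N1CCN(c2ccccc2F)CC1)N1C(=O)CCC1=O` is measured in a functional assay on the whole organism (strain Swiss) with Mus musculus as the target, in the maximal electroshock model, with a stated time of 1 h, at a dose of 300 mg/kg by the intraperitoneal route (on this read-out higher numbers stand for a stronger effect at the one dose given and lower numbers for a weaker effect), and gives 50%. Compound 3 `CCC(C(=O)N1CCN(c2ccc(F)cc2)CC1)N1C(=O)CCC1=O` gives 25% in this assay, and compound 2 `CCC(C(=O)N1CCN(c2ccc(C(F)(F)F)cc2)CC1)N1C(=O)CCC1=O` gives 0%. The step from compound 3 to compound 2 is trifluoromethyl in place of fluoro on an aromatic carbon, and it gave a number 25 percentage points lower from compound 3 to compound 2 (beyond the scatter). How the core of compound 1 differs from that of compound 3 is not broken down here. Compound 4 `CC(C(=O)N1CCN(c2ccccc2C(F)(F)F)CC1)N1C(=O)CCC1=O` carries the change (trifluoromethyl in place of fluoro on an aromatic carbon); this is the same kind of change as from compound 3 to compound 2, but there the place is para to a large group, here ortho to a large group. Among the compounds with values here, compound 4 is expected to show a number 25 percentage points lower from compound 1 to compound 4 (beyond the scatter), because a number 25 percentage points lower from compound 3 to compound 2 (beyond the scatter) is the one measured step of this kind. Compound 4 is estimated at 25%, between 0% and 50%.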

Compound 4, a percentage reported as activity, at one dose (the size of the read-out at that dose, not a potency): 75%
Estimate against measurement, compound 4: 50 percentage points below, and the stated range ends below it.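

Trifluoromethyl in place of fluoro gave a number 25 percentage points higher from compound 1 to compound 4 (beyond the scatter) in this assay. The direction of this change therefore did not carry over from one core to the other: the same change on two cores in this assay, a number 25 percentage points lower (beyond the scatter) from compound 3 to compound 2 and a number 25 percentage points higher (beyond the scatter) from compound 1 to compound 4, 50 percentage points apart, beyond the scatter of two such steps This shows that one measured step of this kind cannot be transferred unchanged within the series, but it does not show what sets the two steps apart, as the two pairs differ both in the core and in where the change sits on the aromatic ring, and the data cannot separate the two.

The compounds shown leave open how each core would respond with the same group placed elsewhere on the aromatic ring. They also leave open whether a chloro, a methoxy or a nitrile at that carbon would follow the fluoro or the trifluoromethyl compounds.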